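This account rests on a few compounds, and the source may have more. Where it says the series, first, only, none or still open, it means among the compounds named here.

Measured compounds in a functional assay on MCF7 cells (Homo sapiens) for cytotoxicity, read by MTT assay, with a stated time of 48 h; on this read-out lower numbers stand for stronger inhibition and higher numbers for weaker inhibition:
Compound 1 `Cc1ccc(S(=O)(=O)Nc2cc(N)cc(-c3cnc4[nH]cc(-c5ccncc5)c4c3)c2)cc1` gives 10400 nM.
Compound 2 `CS(=O)(=O)Nc1cc(N)cc(-c2cnc3[nH]cc(-c4ccncc4)c3c2)c1` gives > 30000 nM, which is a limit of the assay and not a number.

Compound 2 thus stands only at the limit of > 30000 nM in this assay, at which 1 of the 2 values shown sits, with no measured number of its own. Within the data shown here, the only step between the two measured compounds runs an at least 2.8-fold higher number from compound 1 to compound 2 (0.46 log units; beyond the scatter), the replacement of an aryl group on the sulfonyl sulfur by methyl. Compound 3 `Nc1cc(NS(=O)(=O)c2ccc(F)cc2F)cc(-c2cnc3[nH]cc(-c4ccncc4)c3c2)c1` is to be measured in this assay. It differs from compound 2 by 2,4-difluorophenyl in place of methyl on a sulfonyl sulfur, so an aryl group returns to the sulfonyl sulfur in place of methyl, the reverse kind of change to the measured step. For compound 3 a lower number is therefore expected, the step of an at least 2.5-fold lower number from compound 2 to compound 3 (0.39 log units; beyond the scatter), of a size at least like that of the measured step. Compound 1 gives 10400 nM and is the nearest measured anchor. Compound 3 is estimated at 12000 nM, within 4000 nM to 40000 nM.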

Compound 3, half-maximal inhibitory concentration: 6600 nM
Beside the measured number, compound 3's estimate is 1.8-fold (0.26 log units) above it; low and high end bracket the measured number.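

In this assay, among these compounds, a second aryl group on the sulfonyl sulfur gives an at least 4.5-fold lower number from compound 2 to compound 3 (0.65 log units; beyond the scatter), so 4-methylphenyl is no longer the only aryl group that reads beyond the scatter against methyl. Exchanging one aryl group for the other gives a 1.6-fold lower number from compound 1 to compound 3 (0.20 log units; within the scatter), so 2,4-difluorophenyl and 4-methylphenyl are not separated in this pair. The full size of the gap to methyl stays unknown, since compound 2 holds only a limit of the assay and not a number: the limit of > 30000 nM in this assay, at which 1 of the 3 values shown sits.

Going by these compounds, whether an aromatic ring is needed on the sulfonyl sulfur stays open, as a cyclohexyl group or a longer chain such as n-butyl could read with either side. Also open, on these data alone, is how a carboxylic acid or an amine on the aryl ring would read.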